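A few compounds are considered here, and "the series" means these few. Any claim that something is new, unique, unknown or untested is made for them only; others in the source may bear on it.

Measured compounds:
compound 1 `Cn1nc(-c2nnc(SCCOc3ccccc3F)o2)cc1-c1ccc(C(F)(F)F)cc1`, with 25200 nM
compound 2 `Cn1nc(-c2nnc(SCc3cccc(Cl)c3Cl)o2)cc1-c1ccc(C(F)(F)F)cc1`, with 36800 nM
compound 3 `Cn1nc(-c2ccc(C(F)(F)F)cc2)cc1-c1nnc(SCCOc2ccccc2F)o1`, with 35100 nM

Three compounds have been run in a functional assay on Ehrlich cells (Mus musculus) for cytotoxicity, read by MTT assay, with a stated time of 24 h; on this read-out higher numbers stand for weaker inhibition and lower numbers for stronger inhibition. In this assay compound 1 gives 25200 nM, compound 2 gives 36800 nM and compound 3 gives 35100 nM. Compound 1 and compound 2 share a core and differ by one change, (2,3-dichlorophenyl in place of (2-fluorophenoxy)methyl on a saturated chain carbon bound to a sulfur); this change made the step of a 1.5-fold higher number from compound 1 to compound 2 (0.16 log units; within the scatter). Compound 3 is built from the same atoms as compound 1, joined differently; how the two cores differ is not broken down here, and the two values sit within the scatter of each other.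

Within the data shown here, the unmeasured compound 4 `Cn1nc(-c2ccc(C(F)(F)F)cc2)cc1-c1nnc(SCc2cccc(Cl)c2Cl)o1` is obtained from compound 3 by 2,3-dichlorophenyl in place of (2-fluorophenoxy)methyl on a saturated chain carbon bound to a sulfur, which is the same change as the one made from compound 1 to compound 2, at the same place. Because the earlier step of a 1.5-fold higher number from compound 1 to compound 2 (0.16 log units; within the scatter) stayed within the scatter, compound 4 is expected to stay near compound 3, with an estimated step of a 1.3-fold higher number from compound 3 to compound 4 (0.11 log units; within the scatter). On that basis compound 4 is estimated at 45000 nM in this assay, with an expected range from 20000 nM to 100000 nM.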

Compound 4, half-maximal inhibitory concentration: 56500 nM
Estimate against measurement, compound 4: 1.3-fold (0.10 log units) below; the measured number falls inside the stated range.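

In this assay, exchanging 2-(2-fluorophenoxy)ethyl for 2,3-dichlorobenzyl on the core of compound 3 gave a 1.6-fold higher number from compound 3 to compound 4 (0.21 log units; within the scatter). Set beside the earlier step, the change behaved alike on the two cores, with no difference that can be told apart: the same change on two cores in this assay, a 1.5-fold higher number (0.16 log units; within the scatter) from compound 1 to compound 2 and a 1.6-fold higher number (0.21 log units; within the scatter) from compound 3 to compound 4, 1.1-fold (0.04 log units) apart, within the scatter of two such steps. Each step lies within the scatter on its own, however, so this is agreement between two small steps for a single pair of groups, and it does not show that a change with a clear effect would carry from one core to the other.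

All the compounds shown hold a chain on sulfur that ends in a halogen-bearing benzene ring, so it remains open whether the two cores would also keep in step with an amine, a carboxylic acid or a longer chain at that place. On these data alone, whether the same agreement would appear on cells other than those of this single read-out also remains open.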